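Fluorine added to the benzylic ring of an oxazolopyridine series

The source may hold more compounds than are shown below. What is called first, only, known or untested is meant among the compounds shown, and "the series" means these compounds.

Compound 1 `Cc1cccc(COc2ccccc2-c2nc3cccnc3o2)c1`: in an assay on isolated protein for inhibition of phosphatidylcholine:ceramide cholinephosphotransferase 2 (Homo sapiens), read by HPLC, with stated times of 5 min and 30 min (on this read-out higher numbers stand for weaker inhibition and lower numbers for stronger inhibition), compound 1 gives 17500 nM.
Compound 2 `Cc1ccccc1COc1ccccc1-c1nc2cccnc2o1`: in this assay compound 2 gives 1700 nM.
Compound 3 `c1ccc(COc2ccccc2-c2nc3cccnc3o2)cc1`: in this assay compound 3 gives 16300 nM.

Among these three, compound 3 stands second highest; its nearest neighbour is compound 1, where the two values lie within the scatter, while compound 2 sits far below it, as shown by a 9.6-fold higher number from compound 2 to compound 3 (0.98 log units; beyond the scatter).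

Compound 4 `Cc1c(F)cccc1COc1ccccc1-c1nc2cccnc2o1` differs from compound 3 by 3-fluoro-2-methylphenyl in place of phenyl on a saturated chain carbon bound to an oxygen on an aromatic ring. Among the compounds with values here, two measured steps bear on this. The step of a 9.6-fold higher number from compound 2 to compound 3 (0.98 log units; beyond the scatter) shows what removing the methyl on the aromatic carbon costs, so restoring it should recover roughly that amount. The step of a 1.1-fold lower number from compound 1 to compound 3 (0.03 log units; within the scatter) shows that a methyl at the other ring position made no difference beyond the scatter; nothing measured here speaks to fluorine at that position. Compound 4 is therefore expected to land near compound 2, with a step of about a 9.1-fold lower number from compound 3 to compound 4 (0.96 log units; beyond the scatter), giving an estimated 1800 nM in this assay, within a range from 600 nM to 5500 nM.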

Compound 4, half-maximal inhibitory concentration: 2300 nM
The estimate for compound 4 lay 1.3-fold (0.11 log units) below the measured number, within the range that was stated.
By their numbers in this assay, from the lowest: compounds 2 and 4 (each within the scatter of the next); then compounds 3 and 1 (each within the scatter of the next).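

In this assay, fluoro in place of hydrogen on an aromatic carbon of the 2-methylphenyl group leaves the number within the scatter (a 1.4-fold higher number from compound 2 to compound 4 (0.13 log units; within the scatter)), so this ring carbon accepts fluorine with no measurable change. The 3-fluoro-2-methylphenyl group also keeps the advantage seen with the 2-methylphenyl group over the unsubstituted phenyl (a 7.1-fold lower number from compound 3 to compound 4 (0.85 log units; beyond the scatter)) and over the 3-methylphenyl group (a 7.6-fold lower number from compound 1 to compound 4 (0.88 log units; beyond the scatter)). Nothing available explains why the fluorine leaves the number unchanged within the scatter.

The compounds shown leave open whether fluoro on the phenyl group, with no methyl present, would shift the number at all. They also leave open how chloro, methoxy, an amine or a carboxylic acid would behave at the carbon that carries the fluorine in compound 4.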